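The source may report more compounds than this note shows. Statements on the series, on what has been measured and on what is new or still open speak of the compounds shown alone.

The three measured compounds sit close together in an ADME assay on HL-60 cells (Homo sapiens) for cytotoxicity, read by MTT assay, with a stated time of 3 days; a lower number here means that less compound is tolerated, a higher number that more compound is tolerated. Compound 1 `O=c1nc(NO)c(F)cn1[C@@H]1C[C@@H](O)[C@H](CO)O1` gives 1370000 nM in this assay. Compound 2 `Cc1cn([C@@H]2CC[C@H](CO)O2)c(=O)nc1N` gives 950000 nM in this assay, and compound 3 `O=c1nc(NO)ccn1[C@@H]1CC[C@H](CO)O1` gives 1600000 nM. Compound 1 stands second highest of the three numbers; its nearest neighbour is compound 3, whose number lies within the scatter of it, and compound 2, the furthest of the three, is also within the scatter, so on these data none of the three can be set apart from the others.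

Compound 4 `Cc1cn([C@@H]2C[C@@H](O)[C@H](CO)O2)c(=O)nc1NO` has not yet been measured in this assay. It differs from compound 1 by methyl in place of fluoro on an aromatic carbon. For the measured compounds named here, no pair of measured compounds differing in one place is available to calibrate this exchange. Because compound 1 at 1370000 nM, compound 2 at 950000 nM and compound 3 at 1600000 nM all lie within the scatter of one another despite other differences in structure, this exchange is not expected to move the number beyond the scatter in either direction. The step from compound 1 to compound 4 is therefore estimated at a 1.1-fold lower number from compound 1 to compound 4 (0.02 log units; within the scatter). Compound 4 is accordingly expected to give about 1300000 nM in this assay, with a range from 500000 nM to 3000000 nM.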

Compound 4, half-maximal cytotoxic concentration: 600000 nM
Compound 4: the middle estimate sits 2.2-fold (0.34 log units) above what was measured; the measured number falls inside the stated range.
By their numbers in this assay, from the lowest: compounds 4, 2, 1 and 3 (each within the scatter of the next, the first and the last beyond it).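

Replacing fluoro with methyl on the aromatic carbon ortho to the hydroxyamino group gives a 2.3-fold lower number from compound 1 to compound 4 (0.36 log units; beyond the scatter) in this assay. For the compounds shown here, this is the first step at this position that can be read, as the earlier compounds offered no pair differing in one place and their numbers could not be set apart from one another. It shows that this single exchange, which leaves the heavy-atom count, the hydrogen-bond donors and acceptors and the net charge unchanged, can by itself move the number beyond the scatter, although the step is modest and rests on one pair; nothing shown accounts for why the number moves.

The compounds shown leave open whether other groups at this position, such as chloro, ethyl, trifluoromethyl or an amine, would stay with fluoro or with methyl, or give a number of their own. They also leave open whether the same exchange would produce a step of similar size on the core of compound 3, or with an amino group in place of the hydroxyamino group.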